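The source may report more compounds than this note shows. Statements on the series, on what has been measured and on what is new or still open speak of the compounds shown alone.

In a functional assay on BaF3 cells (Mus musculus) for inhibition, read by CCK-8 assay, with a stated time of 72 h (on this read-out higher numbers stand for weaker inhibition of growth and lower numbers for stronger inhibition of growth), compound 1 `CCN1CCN(Cc2ccc(NC(=O)Nc3ccc(Oc4cc(NC(C)=O)ncn4)cc3)cc2C(F)(F)F)CC1` gives 38 nM, so strong inhibition of growth is reachable in this series. In this assay, compound 2 `Cc1ccc(NC(=O)Nc2ccc(Oc3cc(N)ncn3)cc2)cc1C(F)(F)F` gives > 10000 nM, and this is a limit of the read-out and not a number. Among the numbers at hand, compound 2 stands at the limit of > 10000 nM in this assay, at which 1 of the 2 values shown sits.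

Compound 3 `CNCCN(C)c1cc(Oc2ccc(NC(=O)Nc3ccc(C)c(C(F)(F)F)c3)cc2)ncn1` keeps the rest of compound 2 and changes one place: methyl(2-(methylamino)ethyl)amino in place of amino on an aromatic carbon of a six-membered aromatic ring with 2 nitrogen (methyl(2-(methylamino)ethyl)amino in place of amino on an aromatic carbon). Going by the values given here, no measured step speaks to this change directly, and with compound 2 at a limit, the true size of any shift stays open.

A move toward stronger inhibition of growth in this assay is expected because compound 1 reaches 38 nM. Even so, compound 3 may still give a result at the limit, as compound 2 does. The estimated shift is an at least 6.6-fold lower number from compound 2 to compound 3 (0.82 log units; beyond the scatter), and it is expected to be large rather than within the scatter. For compound 3 the estimated value is 1500 nM, with an expected range of 150 nM to 10000 nM.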

Compound 3, concentration for 50% growth inhibition: > 10000 nM
Compound 3: only a limit was reported; the forecaster's own chance of this, stated with the estimate: 25%; middle value at least 6.6-fold (0.82 log units) away from the limit.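

In this assay compound 3 gives > 10000 nM, which is a limit of the read-out and not a number. No step can be read between compound 2 and compound 3: the limit of > 10000 nM in this assay, at which 2 of the 3 values shown sit. The compounds shown leave open whether methyl(2-(methylamino)ethyl)amino in place of amino shifts growth inhibition at all, and by how much.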